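The source may report more compounds than this note shows. Statements on the series, on what has been measured and on what is new or still open speak of the compounds shown alone.

Series notes, kidney half-life. Compound 1 `CC(=O)N/C=C/[S+]([O-])C1=C(C(=O)O)N2C(=O)[C@@H](C(C)(C)OS(=O)(=O)O)[C@H]2C1` gives 0.617 h; 0.367 h (2 entries) in an ADME assay on the whole organism (kidney) for metabolic stability, with Mus musculus as the target (on this read-out lower numbers stand for a shorter-lived compound and higher numbers for a longer-lived compound), and the several entries of compound 1 in this assay, 0.617 h; 0.367 h (2 entries) shows how far repeat entries of one compound lie apart here. Within the data shown here, compound 2 `CC(=O)N/C=C/SC1=C(C(=O)O)N2C(=O)[C@@H](C(C)(C)OS(=O)(=O)O)[C@H]2C1` gives 0.117 h in this assay, the only number it has in this read-out; a further entry for compound 2 carries no single number. Compound 3 `CC(=O)N/C=C\SC1=C(C(=O)O)N2C(=O)[C@@H](C(C)(C)OS(=O)(=O)O)[C@H]2C1` is not yet measured; against compound 2 it shows (the two compounds have the same atoms and bonds and differ only in configuration as drawn: 1 of 3 stereo elements differ; a double bond is drawn E in compound 2 and Z in compound 3). With no measured step of this kind in the set, the expected change a 1.1-fold higher number from compound 2 to compound 3 (0.05 log units; within the scatter) is none beyond the scatter. Compound 3 is estimated at 0.13 h, expected between 0.06 h and 0.3 h.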

Compound 3, half-life: 0.317 h
For compound 3 the middle estimate is 2.4-fold (0.39 log units) below the measured one, outside the stated range (above it).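

Among these compounds, the configuration of the side-chain double bond alone moves the kidney half-life in this assay, the first such change: a 2.7-fold higher number from compound 2 to compound 3 (0.43 log units; beyond the scatter). Nothing else separates the pair, so the step belongs to this double bond: the fact that compounds 2 and 3 differ only in the configuration as drawn. Repeat entries give the spread against which this step is read: the several entries of compound 1 in this assay, 0.617 h; 0.367 h (2 entries).

From the compounds shown here alone, whether the same step appears with the oxidised sulfur of compound 1 remains open. So does whether it persists when a benzoyl group replaces the acetyl group.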